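A few compounds are considered here, and "the series" means these few. Any claim that something is new, unique, unknown or untested is made for them only; others in the source may bear on it.

The three compounds measured so far, each in one assay:

- compound 1, `Oc1cccc(-c2cc(-c3ccccc3)nc(-c3cccs3)c2)c1`, gives 2%
- compound 2, `Oc1cccc(-c2cc(-c3ccccc3)nc(-c3ccsc3)c2)c1`, gives 3.2%
- compound 3, `Oc1cccc(-c2cc(-c3ccccc3)nc(-c3ccncc3)c2)c1`, gives 0.9%

The assay is an assay on isolated protein for inhibition of DNA topoisomerase 1 (Homo sapiens), with a stated time of 30 min, tested at 20 uM; a lower number here means a weaker effect, a higher number a stronger effect of the compound at the concentration tested. In this assay compound 3 holds the lowest of the three numbers, but its gaps to the other two fall inside the usual scatter of repeated measurements, so nothing separates it from compound 1 or compound 2. The three compounds share one core and differ only in the ring attached on one side of it; the steps between them, a number 1.2 percentage points higher from compound 1 to compound 2 (within the scatter), a number 1.1 percentage points lower from compound 1 to compound 3 (within the scatter) and a number 2.3 percentage points lower from compound 2 to compound 3 (within the scatter), are all within the scatter. In short, none of the changes tried so far has moved the read-out.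

Compound 4, `Oc1ccc(-c2cc(-c3ccccc3)nc(-c3ccncc3)c2)cc1`, keeps everything of compound 3 except the position of the hydroxyl group on the attached phenyl ring: 4-hydroxyphenyl in place of 3-hydroxyphenyl on an aromatic carbon. Among the compounds with values here, no measured step touches this part of the molecule, so there is no direct precedent. What the data do show is that every step measured so far stayed within the scatter, with all three compounds sitting near the bottom of the scale.

On that basis the step from compound 3 to compound 4 is expected to stay within the scatter, a number 1.1 percentage points higher from compound 3 to compound 4 (within the scatter). Compound 4 is therefore estimated to give 2% in this assay, with a range from 0% to 12%.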

Compound 4, a percentage reported as inhibition, at one concentration (the size of the read-out at that concentration, not a potency): 5.8%
Compound 4: middle estimate off by 3.8 percentage points, on the low side; the measured number falls inside the stated range.
By their numbers in this assay, from the lowest: compounds 3, 1, 2 and 4 (each within the scatter of the next).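

Within the data shown here, the swap of 3-hydroxyphenyl for 4-hydroxyphenyl is the first change at this position, on an aromatic carbon opposite the ring nitrogen, and in this assay it gives a number 4.9 percentage points higher from compound 3 to compound 4 (within the scatter). The two compounds contain the same atoms and differ only in where the hydroxyl sits on the attached phenyl ring, so this step shows that moving the hydroxyl between these two places does not separate them, just as exchanging the ring on the other side of the shared core did not separate compounds 1, 2 and 3. Nothing available here bears on why the read-out stays so close for this pair.

The compounds shown leave open whether the same move of the hydroxyl would also stay within the scatter with thiophen-2-yl or thiophen-3-yl in place of pyridin-4-yl, since this step was read with pyridin-4-yl alone. They also leave open whether a different group at this spot on the phenyl ring, such as a methoxy group, an amine or a carboxylic acid in place of the hydroxyl, would shift the read-out beyond the scatter.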